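Swapping Methoxy for Acetamido in Compound 1

The source may hold more compounds than are shown below. What is called first, only, known or untested is meant among the compounds shown, and "the series" means these compounds.

Compound 1 `COc1cccc(Nc2nccc(-c3cccnc3)n2)c1` gives 300 nM in a functional assay for inhibition, with Homo sapiens as the target (a lower number here means a stronger inhibitor, a higher number a weaker inhibitor), the second highest of three numbers. Compound 2 `COc1cccc(Nc2nccc(-c3ccco3)n2)c1` gives 400 nM, and compound 3 `COc1cccc(Nc2nccc(-c3ccccn3)n2)c1` gives 200 nM; the steps of a 1.3-fold higher number from compound 1 to compound 2 (0.12 log units; within the scatter), a 1.5-fold lower number from compound 1 to compound 3 (0.18 log units; within the scatter) and a 2.0-fold lower number from compound 2 to compound 3 (0.30 log units; within the scatter) all lie within the scatter. Compound 4 `CC(=O)Nc1cccc(Nc2nccc(-c3cccnc3)n2)c1` differs from compound 1 by acetamido in place of methoxy on an aromatic carbon, on an aromatic carbon of a six-membered aromatic ring of carbon only, meta to a large group. Within the data shown here, none of the three measured steps touches that position; each varies only the ring attached to the shared core, so no measured step bears on this change. The step expected in this assay is no change at the digits printed from compound 1 to compound 4 (within the scatter), nothing beyond the scatter. Compound 4 is estimated at 300 nM, between 100 nM and 1000 nM.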

Compound 4, half-maximal inhibitory concentration: 3600 nM
Beside the measured number, compound 4's estimate is 12-fold (1.08 log units) below it; measured number outside the range, above it.
By their numbers in this assay, from the lowest: compounds 3, 1 and 2 (each within the scatter of the next); then compound 4.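

Compounds 1, 2 and 3 differ only in the ring attached to the shared core, and their steps all lie within the scatter. In this assay, the change at this aromatic carbon gives a 12-fold higher number from compound 1 to compound 4 (1.08 log units; beyond the scatter) and so shows that this position, unlike those ring swaps, can strongly weaken inhibition. No available evidence explains this step.

The compounds shown leave open whether an amine, a hydroxyl or a longer ether chain here would weaken inhibition as acetamido does. They also leave open whether acetamido has the same effect with the furan-2-yl of compound 2 or the pyridin-2-yl of compound 3.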